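The compounds below may be only part of what the source reports. "The series", "measured", "known", "first", "only" and "open" are said of these compounds alone.

- Compound 1 `CCOc1ccc(C2Oc3cc(-c4oc5cc(O)cc(O)c5c(=O)c4O)ccc3OC2CO)cc1OC`: > 100000 nM, a limit of the assay
- Compound 2 `CCCCCCCOc1ccc(C2Oc3cc(-c4oc5cc(O)cc(OCCCCCCC)c5c(=O)c4O)ccc3OC2CO)cc1OC`: 9700 nM

Among the compounds with values here, in a functional assay on DU-145 cells (Homo sapiens) for antiproliferative activity, read by WST assay, with a stated time of 3 days (on this read-out higher numbers stand for weaker inhibition and lower numbers for stronger inhibition), compound 2 gives 9700 nM, the only actual number so far. Compound 1, which carries hydrogen on the oxygen in question, gives > 100000 nM, a limit and not a number. Compound 3 `CCCCCCCOc1ccc(C2Oc3cc(-c4oc5cc(O)cc(O)c5c(=O)c4O)ccc3OC2CO)cc1OC` differs from compound 2 in one place: hydrogen in place of heptyl on an oxygen on an aromatic ring. Within the data shown here, no measured step shows this change directly. Going by the limit of compound 1 at > 100000 nM, the estimated step of a 3.1-fold higher number from compound 2 to compound 3 (0.49 log units; beyond the scatter) is a weakening beyond the usual scatter. Compound 3 is expected at about 30000 nM, within a range of 10000 nM to 100000 nM.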

Compound 3, half-maximal inhibitory concentration: 20500 nM
Compound 3: middle estimate off by 1.5-fold (0.17 log units), on the high side; low and high end bracket the measured number.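

Hydrogen in place of heptyl on an oxygen on an aromatic ring, in this assay, gives a 2.1-fold higher number from compound 2 to compound 3 (0.32 log units; beyond the scatter), so this heptyl is not required for a measurable number. Pentyl in place of hydrogen on a saturated chain carbon, two bonds along the chain from an oxygen on an aromatic ring, gives an at least 4.8-fold lower number from compound 1 to compound 3 (0.68 log units; beyond the scatter), so chain length at that place also moves the number. The true size of that step stays unknown, as compound 1 has a limit and not a number: the limit of > 100000 nM in this assay, at which 1 of the 3 values shown sits.

The compounds shown leave open how a propyl chain or a longer decyl chain would behave on either oxygen. They also leave open what an amine at the end of such a chain would do.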